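A few compounds are considered here, and "the series" means these few. Any claim that something is new, unique, unknown or untested is made for them only; others in the source may bear on it.

Compound 1 `NS(=O)(=O)c1ccc(C(=O)NNC(=O)c2ccccc2)cc1` is the parent of the pair considered here. In an assay on cells for inhibition of Amine oxidase [flavin-containing] B (Homo sapiens), read by fluorescence and spectrophotometry, using microsomes, with a stated time of 20 min (on this read-out lower numbers stand for stronger inhibition and higher numbers for weaker inhibition), compound 1 gives > 100000 nM, which is a limit of the assay rather than a measured number. Compound 1 therefore sits at the limit of > 100000 nM in this assay, at which 1 of the 2 values shown sits, and can only be placed at the weak end of what has been seen. Within the data shown here, compound 2 `N#Cc1ccc(-c2nnc(-c3ccc(S(N)(=O)=O)cc3)o2)cc1` is the one compound with a numerical value: in this assay compound 2 gives 318 nM. Among the measured compounds shown here, no step between measured compounds joins these two structures, so their values show only that compound 2 was resolved and compound 1 was not. Compound 3 `NS(=O)(=O)c1ccc(C(=O)NNC(=O)c2ccc(F)cc2)cc1` differs from compound 1 by fluoro in place of hydrogen on an aromatic carbon, the same difference one bond further out reading phenyl to 4-fluorophenyl. For the measured compounds named here, no measured step informs this change, so no shift beyond the scatter is expected in this assay. Compound 3 is estimated at 150000 nM in this assay, with a range of 30000 nM to 1000000 nM. The expected step that the limit leaves unreadable from compound 1 to compound 3 is none beyond the scatter, and compound 3 is expected most likely to be reported only as a limit.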

Compound 3, half-maximal inhibitory concentration: > 100000 nM
Compound 3: a limit, no number (the forecaster's own chance of this, stated with the estimate: 80%); the middle value lies beyond the limit too.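

No step can be read between compound 1 and compound 3, since both stand as limits rather than numbers in this assay: the limit of > 100000 nM in this assay, at which 2 of the 3 values shown sit. The compounds shown leave open whether fluoro in place of hydrogen on an aromatic carbon shifts inhibition at all, and which structural feature separates the resolved compound 2 from compound 1.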